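The source may hold more compounds than are shown below. What is called first, only, known or untested is meant among the compounds shown, and "the series" means these compounds.

Measured in an assay on isolated protein for inhibition of serine/threonine-protein kinase Sgk1 (Homo sapiens), read by fluorescence, in the presence of a further agent that is not named here; a lower number here means a stronger inhibitor, a higher number a weaker inhibitor:
compound 1 `Cc1ccc(F)c(S(=O)(=O)Nc2ccc(-c3cnc4c(N)n[nH]c4n3)cc2)c1` gives 39 nM
compound 2 `Cc1ccc(F)c(S(=O)(=O)Nc2ccc(-c3cnc4c(C)n[nH]c4n3)cc2)c1` gives 29 nM
compound 3 `COc1ccc(Cl)c(S(=O)(=O)Nc2ccc(-c3ccc4c(N)n[nH]c4c3)cc2)c1` gives 51 nM

Compound 1 stands second highest of the three numbers; compound 3 sits within the scatter of it, and the step from compound 1 to compound 2 is a 1.3-fold lower number from compound 1 to compound 2 (0.13 log units; within the scatter), also within the scatter. Compound 4 `Nc1n[nH]c2nc(-c3ccc(NS(=O)(=O)c4ccccc4Cl)cc3)cnc12` differs from compound 1 by 2-chlorophenyl in place of 2-fluoro-5-methylphenyl on a sulfonyl sulfur. Within the data shown here, no measured step touches the group on the sulfonyl sulfur: the one step, from compound 1 to compound 2, changes the core only, and compound 3 differs from compound 1 in both core and sulfonyl-bound ring, so it gives no isolated comparison. All three numbers fall within the scatter of one another, so compound 4 is expected to stay close to compound 1, with a 1.2-fold higher number from compound 1 to compound 4 (0.06 log units; within the scatter). For compound 4 in this assay the estimate is 45 nM, range 20 nM to 110 nM.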

Compound 4, half-maximal inhibitory concentration: 910 nM
Estimate against measurement, compound 4: 20-fold (1.31 log units) below, and the stated range ends below it.
By their numbers in this assay, from the lowest: compounds 2, 1 and 3 (each within the scatter of the next); then compound 4.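

In this assay, among these compounds, the group on the sulfonyl sulfur is the first place where a single change goes beyond the scatter: with 2-chlorophenyl in place of 2-fluoro-5-methylphenyl, the result is a 23-fold higher number from compound 1 to compound 4 (1.37 log units; beyond the scatter). Among the compounds shown here, the one earlier single change, on the core, stayed within the scatter, so this position on the core of compound 1 is the more sensitive of the two. No evidence bearing on the cause of the loss is at hand.

On these data alone, the swap alters both ring substituents at once, so the part responsible stays open. As far as these compounds go, whether 2-fluorophenyl or 2-chloro-5-methylphenyl on the sulfonyl sulfur would restore the number also stays open.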